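Pyridin-2-yl in Place of 2-Phenylethenyl on the Amide

The source may hold more compounds than are shown below. What is called first, only, known or untested is meant among the compounds shown, and "the series" means these compounds.

Three amides built on a shared core have been tested in a functional assay on SW 1116 cells (Homo sapiens) for antiproliferative activity, read by MTT assay, with a stated time of 48 h; on this read-out higher numbers stand for an effect only at larger amounts of compound and lower numbers for an effect already at smaller amounts. Compound 1 `O=C(Nc1nnc(-c2ccc3c(c2)OCCO3)s1)c1ccccc1` gives 67.6 ug/mL. Compound 2 `Nc1ccc(C(=O)Nc2nnc(-c3ccc4c(c3)OCCO4)s2)cc1` gives 41.2 ug/mL. Compound 3 `O=C(/C=C/c1ccccc1)Nc1nnc(-c2ccc3c(c2)OCCO3)s1` gives 60.2 ug/mL. Among these three numbers compound 3 stands second highest: its nearest neighbour is compound 1 and its furthest is compound 2, yet both gaps are within the scatter, so the three compounds cannot be told apart on this read-out.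

Compound 4 `O=C(Nc1nnc(-c2ccc3c(c2)OCCO3)s1)c1ccccn1` has not yet been measured. It differs from compound 3 in one place: pyridin-2-yl in place of 2-phenylethenyl on a carbonyl carbon. Within the data shown here, two measured steps bear on this change; both alter the same group on the carbonyl carbon. The step of a 1.1-fold lower number from compound 1 to compound 3 (0.05 log units; within the scatter) exchanged phenyl for 2-phenylethenyl, and the step of a 1.5-fold higher number from compound 2 to compound 3 (0.16 log units; within the scatter) exchanged 4-aminophenyl for the same group. Neither moved the number beyond the scatter, so exchanging that group once more, now for pyridin-2-yl, is expected to leave the value in this assay roughly where it is. The estimated step is a 1.0-fold lower number from compound 3 to compound 4 (0.00 log units; within the scatter). Compound 4 is therefore expected to give about 60 ug/mL, with a range from 30 ug/mL to 120 ug/mL.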

Compound 4, half-maximal effective concentration: > 100 ug/mL
Compound 4: no number, only a limit; the forecaster's own chance of this, stated with the estimate: 10%; at least 1.6-fold (0.22 log units) between middle value and limit.
By their numbers in this assay, from the lowest: compounds 2, 3 and 1 (each within the scatter of the next). At a limit, above all of these: compound 4.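

Until now every exchange of the group on the carbonyl carbon stayed within the scatter, but the step of an at least 2.4-fold higher number from compound 2 to compound 4 (0.38 log units; beyond the scatter) passes beyond it, which shows that this position can make a difference in this assay after all. The other two steps, an at least 1.6-fold higher number from compound 3 to compound 4 (0.22 log units; that floor lies within the scatter) and an at least 1.4-fold higher number from compound 1 to compound 4 (0.17 log units; that floor lies within the scatter), have floors inside the scatter, and on their own they do not separate compound 4 from compound 3 or compound 1. As far as these compounds go, compound 4 has a limit and not a number, which makes all three steps floors whose true size stays unknown: the limit of > 100 ug/mL in this assay, at which 1 of the 4 values shown sits.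

The compounds shown leave open what a carboxylic acid, an amine on a saturated chain or a longer carbon chain would do on the same carbonyl carbon. They also leave open whether the one nitrogen that enters with pyridin-2-yl matters at all: compound 1, with phenyl in that place, differs from compound 4 by that nitrogen, yet the floor of their step lies within the scatter.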